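Swapping a bromine for a nitrile on a short side chain

The compounds below may be only part of what the source reports. "The series", "measured", "known", "first", "only" and "open" are said of these compounds alone.

Of the compounds shown here, three built on one shared core have so far been tested in an assay on brain (strain Sprague-Dawley) for inhibition of Amine oxidase [flavin-containing] B (Rattus norvegicus), read by spectrophotometry; on this read-out higher numbers stand for weaker inhibition and lower numbers for stronger inhibition. Compound 1 `O=C(O)COc1cc(=O)oc2cc(OCc3cccc(Cl)c3)ccc12` gives 31600 nM. Compound 2 `O=c1cc(CCCl)c2ccc(OCc3cccc(Cl)c3)cc2o1` gives 12.9 nM, and compound 3 `O=c1cc(CCBr)c2ccc(OCc3cccc(Cl)c3)cc2o1` gives 32.4 nM. Compound 3 therefore stands second of the three: it sits a little above compound 2, as shown by a 2.5-fold higher number from compound 2 to compound 3 (0.40 log units; beyond the scatter), and far below compound 1, as shown by a 980-fold lower number from compound 1 to compound 3 (2.99 log units; beyond the scatter).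

The next compound, compound 4 `N#CCCc1cc(=O)oc2cc(OCc3cccc(Cl)c3)ccc12`, differs from compound 3 by cyano in place of bromo on a saturated chain carbon, two bonds along the chain from an aromatic carbon. Two kinds of measured step bear on this change. Exchanging one halogen for the other on the same chain carbon, a 2.5-fold higher number from compound 2 to compound 3 (0.40 log units; beyond the scatter), was modest. Replacing carboxymethoxy by a 2-haloethyl chain, a 2400-fold lower number from compound 1 to compound 2 (3.39 log units; beyond the scatter) and a 980-fold lower number from compound 1 to compound 3 (2.99 log units; beyond the scatter), was large, so the group at this position governs the outcome in this assay. For the measured compounds named here, no measured step covers a cyano group here. Since compound 4 keeps the two-carbon chain and only exchanges its terminal group, the change is expected to be a moderate weakening, a 3.7-fold higher number from compound 3 to compound 4 (0.57 log units; beyond the scatter), with wide uncertainty. Compound 4 is estimated at 120 nM, within a range from 20 nM to 800 nM.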

Compound 4, half-maximal inhibitory concentration: 28.8 nM
The estimate for compound 4 lay 4.2-fold (0.62 log units) above the measured number, within the range that was stated.
By their numbers in this assay, from the lowest: compound 2; then compounds 4 and 3 (each within the scatter of the next); then compound 1.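

At this place on the chain, the nitrile and the bromine cannot be told apart in this assay (a 1.1-fold lower number from compound 3 to compound 4 (0.05 log units; within the scatter)), so this end group need not be a halogen for the number to stay close to that of compound 3. The large distance from the carboxymethoxy compound also holds for 2-cyanoethyl (a 1100-fold lower number from compound 1 to compound 4 (3.04 log units; beyond the scatter)), which extends what the two 2-haloethyl compounds had shown to a group that has a triple bond and a hydrogen-bond acceptor. Compound 2 nevertheless keeps a modest lead over the nitrile (a 2.2-fold higher number from compound 2 to compound 4 (0.35 log units; beyond the scatter)), so among the three compounds with a substituted ethyl chain, the chloro end group is the one that stands apart, while the bromo and cyano end groups do not separate. No evidence is at hand on why these end groups compare as they do.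

The compounds shown leave open whether 2-aminoethyl or 2-hydroxyethyl would stay in the same range as these end groups. They also leave open whether a longer chain ending in a nitrile would hold this level or lose it.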